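Carbamoyl for methylsulfonyl on the shared core

The source may hold more compounds than are shown below. What is called first, only, known or untested is meant among the compounds shown, and "the series" means these compounds.

Compound 1 `CS(=O)(=O)c1ccc(C(=O)N2CCC(N(C3CC3)S(=O)(=O)c3cccc(C(F)(F)F)c3)CC2)cc1` has no result in an assay on cells for inhibition of Voltage-dependent L-type calcium channel subunit alpha-1C (Homo sapiens), read by FLIPR and calcium flux, tested at 1 uM; a higher number here means a stronger effect of the compound at the concentration tested, a lower number a weaker effect; its entry there reads "not determined" (no result reported), so compound 1 stands nowhere on the numbers shown. Two related compounds were measured: compound 2 `O=C(c1cccc(OC(F)(F)F)c1)N1CCC(N(C2CC2)S(=O)(=O)c2cccc(C(F)(F)F)c2)CC1` gives 60% in this assay, and compound 3 `O=C(c1ccc(OC(F)(F)F)cc1)N1CCC(N(C2CC2)S(=O)(=O)c2cccc(C(F)(F)F)c2)CC1` gives 73%, a step of a number 13 percentage points higher from compound 2 to compound 3 (beyond the scatter). Compound 4 `NC(=O)c1ccc(C(=O)N2CCC(N(C3CC3)S(=O)(=O)c3cccc(C(F)(F)F)c3)CC2)cc1` differs from compound 1 by carbamoyl in place of methylsulfonyl on an aromatic carbon. Within the data shown here, no measured step covers that exchange; the only step known concerns where the trifluoromethoxy group sits, so it does not bear on the size or direction to expect. Compound 4 is therefore expected to fall near the two measured compounds, estimated at 55% with a range from 25% to 80%.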

Compound 4, a percentage reported as inhibition, at one concentration (the size of the read-out at that concentration, not a potency): 0%
For compound 4 the middle estimate is 55 percentage points above the measured one; measured number below the stated range.
By their numbers in this assay, from the lowest: compound 4; then compound 2; then compound 3.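

In this assay, carbamoyl in place of trifluoromethoxy gives a number 73 percentage points lower from compound 3 to compound 4 (beyond the scatter), and 4-carbamoylphenyl in place of 3-(trifluoromethoxy)phenyl gives a number 60 percentage points lower from compound 2 to compound 4 (beyond the scatter). The earlier compounds shown here showed only a modest shift with the place of the trifluoromethoxy group, whereas these steps show that the group on this aromatic ring can take the read-out away entirely. Nothing given here accounts for the drop. Where the methylsulfonyl of compound 1 stands remains open. So does whether a nitrile, an amine or a carboxylic acid here would follow carbamoyl or trifluoromethoxy.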